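A few compounds are considered here, and "the series" means these few. Any claim that something is new, unique, unknown or untested is made for them only; others in the source may bear on it.

Compound 1 `CN(C)C(=O)c1cc2cnc(Nc3ccc(NC(=O)C4(C(=O)Nc5ccc(Br)cc5)CC4)cc3)nc2n1C1CCCC1` carries a 4-bromophenyl group on one of its amide-type nitrogens. In a functional assay on A549 cells (Homo sapiens) for inhibition, read by CCK-8 assay, with a stated time of 72 h, tested at 10 uM (on this read-out lower numbers stand for less inhibition of growth and higher numbers for more inhibition of growth at the one concentration tested), compound 1 gives 90.3%. Its nearest relative, compound 2 `Cc1cccc(NC(=O)C2(C(=O)Nc3ccc(Nc4ncc5cc(C(=O)N(C)C)n(C6CCCC6)c5n4)cc3)CC2)c1`, has 3-methylphenyl in place of 4-bromophenyl on that nitrogen; in this assay compound 2 gives 86.1%. The step of a number 4.2 percentage points lower from compound 1 to compound 2 (within the scatter) shows two readings that cannot be told apart. On the numbers shown, compound 1 stands at the top of the two, yet the gap to compound 2 lies within the scatter, so no ranking follows.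

Compound 3 `CN(C)C(=O)c1cc2cnc(Nc3ccc(NC(=O)C4(C(=O)Nc5ccc(Cl)cc5)CC4)cc3)nc2n1C1CCCC1` differs from compound 1 by chloro in place of bromo on an aromatic carbon. Within the data shown here, no measured step swaps one halogen for another; the only step known, a number 4.2 percentage points lower from compound 1 to compound 2 (within the scatter), exchanges the whole 4-bromophenyl for 3-methylphenyl and still stays within the scatter. A swap of one heavy atom for one heavy atom is expected to do no more, so the expected step of a number 2.3 percentage points lower from compound 1 to compound 3 (within the scatter) is none beyond the scatter. Compound 3 is therefore estimated to give 88%, with a likely range from 78% to 96%.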

Compound 3, percent growth inhibition at one concentration: 101%
Compound 3: the middle estimate sits 13 percentage points below what was measured; measured number above the stated range.
By their numbers in this assay, from the lowest: compounds 2 and 1 (each within the scatter of the next); then compound 3.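

Exchanging one atom, chloro in place of bromo on an aromatic carbon para to a large group, gives a number 10.7 percentage points higher from compound 1 to compound 3 (beyond the scatter) in this assay and so moves the reading by more than the scatter. The two earlier compounds could not show this, as their whole-group exchange stayed within the scatter, whereas the exchange of 3-methylphenyl for 4-chlorophenyl gives a number 14.9 percentage points higher from compound 2 to compound 3 (beyond the scatter) and places compound 3 clearly apart from both other compounds. Nothing available explains why chloro and bromo read differently here.

As far as these compounds go, whether fluoro, methoxy or an amine at this place would read closer to chloro or to bromo remains open. So does the question of whether chloro elsewhere on the same ring would keep the higher reading.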